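Exchanging the bicyclic group on compound 3

The compounds below may be only part of what the source reports. "The series", "measured", "known", "first", "only" and "open" are said of these compounds alone.

In a functional assay on DU-145 cells (Homo sapiens) for inhibition, read by trypan blue exclusion, with a stated time of 72 h (on this read-out higher numbers stand for weaker inhibition and lower numbers for stronger inhibition), compound 1 `Cn1c(=O)c(S(=O)(=O)c2ccc(C(=O)O)cc2)cc2cnc(Nc3ccc4[nH]ccc4c3)nc21` gives 10000 nM, compound 2 `Cn1c(=O)c(S(=O)(=O)c2ccc(F)cc2)cc2cnc(Nc3ccc4occc4c3)nc21` gives 5000 nM, and compound 3 `Cn1c(=O)c(S(=O)(=O)c2ccc(F)cc2F)cc2cnc(Nc3ccc4occc4c3)nc21` gives 15000 nM. Compound 3 thus lies within the scatter of compound 1, while its gap to compound 2 goes beyond the scatter, as a 3.0-fold higher number from compound 2 to compound 3 (0.48 log units; beyond the scatter) shows.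

Compound 4 `Cn1ccc2cc(Nc3ncc4cc(S(=O)(=O)c5ccc(F)cc5F)c(=O)n(C)c4n3)ccc21` keeps the rest of compound 3 and changes one group: 1-methyl-1H-indol-5-yl in place of 1-benzofuran-5-yl on a nitrogen on an aromatic ring. In words, 1-methyl-1H-indol-5-yl stands in place of 1-benzofuran-5-yl on a nitrogen on an aromatic ring.

For the measured compounds named here, no measured step covers this exchange. The one available, a 3.0-fold higher number from compound 2 to compound 3 (0.48 log units; beyond the scatter), concerns a fluoro on an aromatic carbon and bears on it only as a sign that a small edit can produce a modest step. Compound 1 differs from compound 3 in more than one place, so its value isolates nothing.

No step beyond the scatter is therefore expected, and the estimated change is a 1.5-fold lower number from compound 3 to compound 4 (0.18 log units; within the scatter). For compound 4 the expected value is 10000 nM, with an estimated range of 3500 nM to 30000 nM.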

Compound 4, half-maximal inhibitory concentration: 750 nM
Beside the measured number, compound 4's estimate is 13-fold (1.12 log units) above it; measured number outside the range, below it.
By their numbers in this assay, from the lowest: compound 4; then compounds 2, 1 and 3 (each within the scatter of the next, the first and the last beyond it).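

In this assay, for the compounds shown here, the exchange of the bicyclic group gives a 20-fold lower number from compound 3 to compound 4 (1.30 log units; beyond the scatter), the first large step. Going by these compounds alone, the only earlier step, a 3.0-fold higher number from compound 2 to compound 3 (0.48 log units; beyond the scatter), came from a fluoro on an aromatic carbon and was modest, whereas this result shows that the group on a nitrogen on an aromatic ring can shift the number much further, even though 1-benzofuran-5-yl and 1-methyl-1H-indol-5-yl have the same ring types and the same donor and acceptor counts. Nothing available explains why this exchange has so large an effect.

From the compounds shown here alone, it remains open whether the step belongs to the ring nitrogen or to its methyl, and how an ethyl or a longer chain in place of that methyl would read. Also open, going by these compounds, is whether the fluoro step seen with 1-benzofuran-5-yl would recur with 1-methyl-1H-indol-5-yl.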